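Taking the fluoro off compound 1

A few compounds are considered here, and "the series" means these few. Any claim that something is new, unique, unknown or untested is made for them only; others in the source may bear on it.

In an ADME assay on microsomes (Mus musculus) for metabolic stability, read by LC-MS, using NADPH, with a stated time of 1 h, tested at 1 uM (on this read-out higher numbers stand for fast clearance and lower numbers for slow clearance), compound 1 (`Nc1n[nH]c2cc(-c3ccc(=O)n(Cc4ccccc4F)c3)ccc12`) gives < 10 mL.min-1.g-1 as a limit of the assay and not a number. Compound 1 thus stands at the limit of < 10 mL.min-1.g-1 in this assay, at which 2 of the 3 values shown sit, and its exact place cannot be read. Compound 3 (`Nc1n[nH]c2cc(-c3ccc(=O)n(Cc4cccc(F)c4)c3)ccc12`) gives < 10 mL.min-1.g-1 as a limit too. Compound 2 (`O=c1ccc(-c2ccc3cn[nH]c3c2)cn1Cc1ccccc1`), with benzyl on a different core, gives 157 mL.min-1.g-1 as a true number, which is not carried over here.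

Compound 4 (`Nc1n[nH]c2cc(-c3ccc(=O)n(Cc4ccccc4)c3)ccc12`) keeps the core of compound 1 and has hydrogen in place of fluoro on an aromatic carbon, ortho to a large group (hydrogen in place of fluoro on an aromatic carbon), so that 2-fluorobenzyl becomes benzyl. For the measured compounds named here, the one measured step that bears on this is a step that the two limits leave unreadable from compound 1 to compound 3 with 3-fluorophenyl in place of 2-fluorophenyl, and it offers no size to carry over. Going by the values given here, no measured compound has the core of compound 1 without fluoro. As far as these compounds go, a change within the usual scatter is therefore expected, with no firm direction, though the upper side stays open. Estimated here is a number no lower from compound 1 to compound 4 (the limit leaves the size open) as the expected step. The estimate for compound 4 is 10 mL.min-1.g-1 with an expected range from 5 mL.min-1.g-1 to 30 mL.min-1.g-1 and the assay may well report only a limit again.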

Compound 4, intrinsic clearance in microsomes: < 10 mL.min-1.g-1
Compound 4: no number, only a limit (the forecaster's own chance of this, stated with the estimate: 60%); the middle value sits exactly at the limit.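

With hydrogen in place of fluoro on an aromatic carbon, compound 4 is a limit of the assay and not a number, like compound 1 and compound 3, so the steps among these three cannot be read. Fluoro at this place is therefore not required for a compound with this core to reach that limit: the limit of < 10 mL.min-1.g-1 in this assay, at which 3 of the 4 values shown sit. For the compounds shown here, compound 4 also gives the first readable step to the core of compound 1 from a compound that differs in one place: in this assay, amino in place of hydrogen on an aromatic carbon gives an at least 15-fold lower number from compound 2 to compound 4 (1.19 log units; beyond the scatter).

Any true differences among hydrogen, 2-fluorobenzyl and the 3-fluorophenyl compound remain hidden behind the limit, so the compounds shown cannot rank them, and they do not tell whether fluoro would change the much higher number of compound 2, which has no amino group. Nor do they show whether chloro or methoxy at this place on the benzyl ring, or a methylamine in place of the amino group, would give a number that can be read.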